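The source may report more compounds than this note shows. Statements on the series, on what has been measured and on what is new or still open speak of the compounds shown alone.

In an assay on isolated protein for displacement of a labelled ligand from 5-hydroxytryptamine receptor 6 (Homo sapiens), read by scintillation counting, with a stated time of 1 h (a lower number here means a stronger inhibitor, a higher number a weaker inhibitor), compound 3 `O=S(=O)(c1ccccc1)n1ccc2cc(N3CCCCC3)ccc21` gives 360 nM, the second highest of the three numbers measured. Compound 1 `CC(=O)N1CCN(c2cccc3c2ccn3S(=O)(=O)c2ccccc2)CC1` gives 714 nM in this assay, which lies within the usual scatter of compound 3. Compound 2 `CN1CCN(c2ccc3c(ccn3S(=O)(=O)c3ccccc3)c2)CC1` gives 27 nM, and the step of a 13-fold higher number from compound 2 to compound 3 (1.12 log units; beyond the scatter) shows how much exchanging 4-methylpiperazin-1-yl for piperidin-1-yl costs. Compound 4 `O=S(=O)(c1ccccc1)n1ccc2cc(-c3ccncc3)ccc21` has not been measured; it differs from compound 3 by pyridin-4-yl in place of piperidin-1-yl on an aromatic carbon. Among the measured compounds shown here, no measured step exchanges a saturated ring for an aromatic one at this place, so the measured steps give little guidance here. For compound 4 the expected step is a 1.9-fold higher number from compound 3 to compound 4 (0.29 log units; within the scatter), without a clear direction beyond the scatter. Compound 4 is therefore estimated at 700 nM, between 200 nM and 2500 nM.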

Compound 4, inhibition constant: 409 nM
For compound 4 the middle estimate is 1.7-fold (0.23 log units) above the measured one; the range from low to high includes it.
By their numbers in this assay, from the lowest: compound 2; then compounds 3, 4 and 1 (each within the scatter of the next).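

In this assay, among the compounds shown here, swapping the non-aromatic piperidin-1-yl ring for the aromatic pyridin-4-yl ring on this aromatic carbon gives a 1.1-fold higher number from compound 3 to compound 4 (0.06 log units; within the scatter), so the earlier compounds' silence on this exchange is answered with no readable difference. A second replacement for 4-methylpiperazin-1-yl also gives a large step, a 15-fold higher number from compound 2 to compound 4 (1.18 log units; beyond the scatter), so that large step is not unique to piperidin-1-yl. Nothing measured here explains these results.

On these data alone, it remains open how the unsubstituted piperazin-1-yl ring or an open-chain amine such as dimethylamino would compare with compound 2 at this place.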